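The compounds below may be only part of what the source reports. "The series", "measured", "known", "first", "only" and "open" are said of these compounds alone.

Compound 3 `O=C(Nc1cccc(-c2nc3ccccc3s2)c1)c1ccc(Cl)nc1Cl` stands second highest of the three numbers in a physicochemical assay for solubility, in phosphate buffer, measured as kinetic solubility, with a stated time of 18 h, at pH 7.4 (on this read-out higher numbers stand for higher solubility and lower numbers for lower solubility), where compound 3 gives 350 nM. Its nearest neighbour is compound 1 `C=CC(=O)Nc1cccc(-c2nc3ccccc3s2)c1`, which gives 180 nM; the step of a 1.9-fold higher number from compound 1 to compound 3 (0.29 log units; within the scatter). Furthest off is compound 2 `O=C(O)/C=C/C(=O)Nc1cccc(-c2nc3ccccc3s2)c1`, which gives 56000 nM; the step of a 160-fold lower number from compound 2 to compound 3 (2.20 log units; beyond the scatter). Compound 4 `O=C(Nc1cccc(-c2nc3ccccc3s2)c1)c1ccnc(Cl)c1` carries the change (2-chloropyridin-4-yl in place of 2,6-dichloropyridin-3-yl on a carbonyl carbon). Neither measured step swaps one pyridine for another: the step from compound 1 to compound 3 exchanged vinyl for the dichloropyridine and stayed within the scatter, while the large step from compound 2 rests on a 2-carboxyethenyl group that compound 4 lacks. The step of a 1.4-fold higher number from compound 3 to compound 4 (0.15 log units; within the scatter) is therefore expected to stay within the scatter. Compound 4 is estimated at 500 nM, within 150 nM to 1600 nM.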

Compound 4, solubility: 740 nM
Estimate against measurement, compound 4: 1.5-fold (0.17 log units) below; measured number inside the range.
By their numbers in this assay, from the lowest: compounds 1 and 3 (each within the scatter of the next); then compound 4; then compound 2.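

In this assay this position responds even when one chlorinated pyridine replaces another, with one chlorine fewer in the entering group (a 2.1-fold higher number from compound 3 to compound 4 (0.33 log units; beyond the scatter)). The 2-chloropyridin-4-yl group also stands clear of vinyl (a 4.1-fold higher number from compound 1 to compound 4 (0.61 log units; beyond the scatter)), which 2,6-dichloropyridin-3-yl did not, but it remains far from the 2-carboxyethenyl compound (a 76-fold lower number from compound 2 to compound 4 (1.88 log units; beyond the scatter)). Nothing available here accounts for these differences. On these data alone, the lost chlorine and the changed ring attachment come together, so their separate contributions stay open. Also open, as far as these compounds go, is how a pyridine carrying an amine or a carboxylic acid would read.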